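A few compounds are considered here, and "the series" means these few. Any claim that something is new, unique, unknown or untested is made for them only; others in the source may bear on it.

The measured compounds:
compound 1, `CCCCCSc1nc(C(F)(F)F)ccc1CNC(=O)C(C)c1ccc(NS(C)(=O)=O)c(F)c1`, with 2.5 nM in an assay on CHO-K1 cells for antagonist activity at transient receptor potential cation channel subfamily V member 1 (Homo sapiens), read by FLIPR; a lower number here means a stronger inhibitor, a higher number a weaker inhibitor;
compound 2, `CC(C(=O)NCc1ccc(C(F)(F)F)nc1SCCCN1CCCCC1)c1ccc(NS(C)(=O)=O)c(F)c1`, with 3 nM in this assay.

Within the data shown here, compound 2 gives the higher of the two numbers, yet its only neighbour, compound 1, sits within the scatter of it, as the step of a 1.2-fold higher number from compound 1 to compound 2 (0.08 log units; within the scatter) shows. Compound 3, `CC(C(=O)NCc1ccc(C(F)(F)F)nc1SCCC(=O)N1CCCC1)c1ccc(NS(C)(=O)=O)c(F)c1`, differs from compound 2 on a saturated chain carbon, two bonds along the chain from a sulfur: (pyrrolidin-1-yl)carbonyl in place of (piperidin-1-yl)methyl on a saturated chain carbon, two bonds along the chain from a sulfur. Among the measured compounds shown here, the single measured step that touches this chain is a 1.2-fold higher number from compound 1 to compound 2 (0.08 log units; within the scatter), where a piperidinyl ring replaced an ethyl and the number barely moved. For the measured compounds named here, no measured pair shows a carbonyl on this chain, so the expectation rests on that one step alone. Compound 3 is therefore expected to stay close to compound 2, with an estimated step of a 1.3-fold higher number from compound 2 to compound 3 (0.12 log units; within the scatter). The estimate for compound 3 in this assay is 4 nM, expected to lie between 1.5 nM and 12 nM.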

Compound 3, inhibition constant: 85 nM
Estimate against measurement, compound 3: 21-fold (1.33 log units) below; the measured number lies above the stated range.
By their numbers in this assay, from the lowest: compounds 1 and 2 (each within the scatter of the next); then compound 3.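

The position on the saturated chain carbon, two bonds along the chain from a sulfur, turns out to be sensitive to what sits there: (pyrrolidin-1-yl)carbonyl in place of (piperidin-1-yl)methyl gives a 28-fold higher number from compound 2 to compound 3 (1.45 log units; beyond the scatter) and, against the plain chain of compound 1, the same group gives a 34-fold higher number from compound 1 to compound 3 (1.53 log units; beyond the scatter) even though a 1.2-fold higher number from compound 1 to compound 2 (0.08 log units; within the scatter) had suggested that the chain accepts large changes. The two groups match in heavy atoms and hydrogen-bond acceptors, so those counts do not separate them, and the change combines a new carbonyl with a smaller ring. Nothing measured here explains this loss of strength.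

A pyrrolidine ring without the carbonyl, or a piperidine ring with it, would show which of the two changes matters. From the compounds shown here alone, how an open-chain amine, a carboxylic acid or a longer chain would fare at this position also remains open.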